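The source may hold more compounds than are shown below. What is called first, only, known or untested is meant among the compounds shown, and "the series" means these compounds.

Working notes on the series in a functional assay (brain) for inhibition, with Rattus norvegicus as the target; on this read-out higher numbers stand for weaker inhibition and lower numbers for stronger inhibition. Compound 1 (`CN(C)CC/C=C(\c1ccc(Br)cc1)c1cccnc1`) gives 2600 nM, and its partner about the double bond, compound 2 (`CN(C)CC/C=C(/c1ccc(Br)cc1)c1cccnc1`), gives 500 nM. Compound 3 (`CNCC/C=C(\c1ccc(Br)cc1)c1cccnc1`) gives 1400 nM. For the measured compounds named here, that value lies within the scatter of compound 1 and is a clearly higher number than the one for compound 2.

The open compound is compound 4 (`CNCC/C=C(/c1ccc(Br)cc1)c1cccnc1`). The structural change is the two compounds have the same atoms and bonds and differ only in configuration as drawn: 1 of 1 stereo elements differ; a double bond is drawn E in compound 3 and Z in compound 4; nothing leaves and nothing enters.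

Going by the values given here, two measured steps bear on this. The closest is a 5.2-fold lower number from compound 1 to compound 2 (0.72 log units; beyond the scatter), the same change of the double bond from E to Z, made with the second methyl still on the amine nitrogen. That step can be tied to configuration alone because of the fact that compounds 1 and 2 differ only in the configuration as drawn. The other is a 1.9-fold lower number from compound 1 to compound 3 (0.27 log units; within the scatter), hydrogen in place of methyl on an amine nitrogen, and it stays within the scatter. It therefore gives no ground for expecting the double-bond step to differ once that methyl is gone. Among the compounds with values here, only one such pair has been measured, so the transfer rests on a single step and the range is kept wide.

The expected change is a 5.2-fold lower number from compound 3 to compound 4 (0.71 log units; beyond the scatter), towards a lower number and of similar size to the step on the double bond. For compound 4 the estimate is 270 nM, with an expected range of 110 nM to 700 nM.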

Compound 4, half-maximal inhibitory concentration: 240 nM
Estimate against measurement, compound 4: 1.1-fold (0.05 log units) above; low and high end bracket the measured number.
By their numbers in this assay, from the lowest: compound 4; then compound 2; then compounds 3 and 1 (each within the scatter of the next).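

The double-bond change now has a second measured pair in this assay: a 5.8-fold lower number from compound 3 to compound 4 (0.77 log units; beyond the scatter), which goes the same way as a 5.2-fold lower number from compound 1 to compound 2 (0.72 log units; beyond the scatter), so in both pairs shown the Z compound carries the lower number, with one methyl or two on the amine nitrogen. The new step can be attributed to configuration alone because of this: the fact that compounds 3 and 4 differ only in the configuration as drawn. Hydrogen in place of methyl on an amine nitrogen also gains a second reading, a 2.1-fold lower number from compound 2 to compound 4 (0.32 log units; beyond the scatter), and although this step lies beyond the scatter where the first did not, the two readings do not separate, so the change behaves alike on both double-bond forms: the same change on two cores in this assay, a 1.9-fold lower number (0.27 log units; within the scatter) from compound 1 to compound 3 and a 2.1-fold lower number (0.32 log units; beyond the scatter) from compound 2 to compound 4, 1.1-fold (0.05 log units) apart, within the scatter of two such steps.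

On these data alone, the amine nitrogen carries only methyl or hydrogen in these compounds, so it remains open whether the Z compound keeps the lower number with a primary amine or with an ethyl group on that nitrogen. Also open, as far as these compounds go, is whether the double-bond step keeps its direction and size with chlorine in place of the bromine, or with a longer chain between the double bond and the amine.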